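The compounds below may be only part of what the source reports. "The series", "measured", "known", "first", "only" and "open" are said of these compounds alone.

Values measured in an in vivo ADME assay on the whole organism (strain Sprague-Dawley) for pharmacokinetics, with Rattus norvegicus as the target, at a dose of 2 mg/kg by the oral route (on this read-out lower numbers stand for lower oral bioavailability and higher numbers for higher oral bioavailability), so far
- Compound 1 `Cc1cc([C@@H]2C[C@H]2C(=O)O)ccc1-c1noc(-c2ccc(OC(C)C)c(C(F)(F)F)c2)n1` gives 88%
- Compound 2 `Cc1cc(C(C)CC(=O)O)ccc1-c1noc(-c2ccc(OC(C)C)c(C(F)(F)F)c2)n1` gives 100%
- Compound 3 `Cc1cc(CC(C)C(=O)O)ccc1-c1noc(-c2ccc(OC(C)C)c(C(F)(F)F)c2)n1` gives 82%

Compound 3 stands at 82%, within the scatter of compound 1 and clearly short of compound 2. Compound 4 `Cc1cc(CCC(=O)O)ccc1-c1noc(-c2ccc(OC(C)C)c(C(F)(F)F)c2)n1` differs from compound 3 at one place, (hydrogen in place of methyl on a saturated chain carbon bound to a carbonyl carbon and a saturated chain carbon), so that 2-carboxypropyl becomes 2-carboxyethyl. Among the compounds with values here, no measured step removes this methyl outright. The nearest evidence comes from exchanges among the carboxy-bearing groups on an aromatic carbon: a number 12 percentage points higher from compound 1 to compound 2 (beyond the scatter), a number 6 percentage points lower from compound 1 to compound 3 (within the scatter) and a number 18 percentage points lower from compound 2 to compound 3 (beyond the scatter). These steps are modest or within the scatter, and they do not agree in direction, so only a small change is expected here, with no firm direction. The expected change is a number 2 percentage points lower from compound 3 to compound 4 (within the scatter), which means no step beyond the scatter is anticipated. For compound 4 the estimated value in this assay is 80%, with an expected range from 57% to 100%.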

Compound 4, oral bioavailability: 88%
Beside the measured number, compound 4's estimate is 8 percentage points below it; the measured number falls inside the stated range.
By their numbers in this assay, from the lowest: compounds 3, 1 and 4 (each within the scatter of the next); then compound 2.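

In this assay, the hydrogen in place of methyl on a saturated chain carbon bound to a carbonyl carbon and a saturated chain carbon gives a number 6 percentage points higher from compound 3 to compound 4 (within the scatter), so this read-out does not separate 2-carboxypropyl from 2-carboxyethyl. The 2-carboxycyclopropyl group also reads the same as 2-carboxyethyl, with no change at the digits printed from compound 1 to compound 4 (within the scatter), which adds a direct match between the cyclopropyl group and the open chain. The same exchange of methyl for hydrogen on a saturated chain carbon bound to an aromatic carbon instead gives a number 12 percentage points lower from compound 2 to compound 4 (beyond the scatter), so among these four compounds only compound 2 stands apart from the rest.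

The compounds shown leave open how a longer chain ending in the carboxylic acid, or an amide in its place, would read. No accompanying measurement explains any of these steps.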